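Swapping the aryl group on a fused core

The source may hold more compounds than are shown below. What is called first, only, known or untested is meant among the compounds shown, and "the series" means these compounds.

Compound 1, `COc1cc(-c2ccnc3cc(-c4ccc(C(C)(C)C)cc4)nn23)cc(OC)c1OC`: in a functional assay on B16-F0 cells (Mus musculus) for inhibition, read by CCK-8 assay, with a stated time of 48 h (on this read-out higher numbers stand for weaker inhibition and lower numbers for stronger inhibition), compound 1 gives a limit, > 10000 nM.
Compound 2, `COc1ccc(-c2cc3nccc(-c4cc(OC)c(OC)c(OC)c4)n3n2)cc1`: compound 2 gives 1410 nM.
Compound 3, `COc1cc(-c2ccnc3cc(-c4ccc(C)c(C)c4)nn23)cc(OC)c1OC`: compound 3 gives 391 nM.

Compound 3 holds the lowest of the two numbers, and the step of a 3.6-fold lower number from compound 2 to compound 3 (0.56 log units; beyond the scatter) lies beyond the scatter. Compound 4, `COc1cc(-c2ccnc3cc(-c4cccc(C#N)c4)nn23)cc(OC)c1OC`, differs from compound 3 in one place: 3-cyanophenyl in place of 3,4-dimethylphenyl on an aromatic carbon. Two earlier steps changed this same group and both bear on it: an at least 25-fold lower number from compound 1 to compound 3 (1.40 log units; beyond the scatter) and a 3.6-fold lower number from compound 2 to compound 3 (0.56 log units; beyond the scatter). The value of compound 1 is only a limit (the limit of > 10000 nM in this assay, at which 1 of the 3 values shown sits). Since each change away from 3,4-dimethylphenyl so far gave a higher number, compound 4 is expected to show a modest rise, a 2.3-fold higher number from compound 3 to compound 4 (0.36 log units; beyond the scatter). Compound 4 is therefore estimated at 900 nM, within 250 nM to 3500 nM.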

Compound 4, half-maximal inhibitory concentration: > 10000 nM
Compound 4 was reported as a limit (the forecaster's own chance of this, stated with the estimate: 10%); at least 11-fold (1.04 log units) between middle value and limit.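

At this position on the shared core, 3-cyanophenyl in place of 3,4-dimethylphenyl gives an at least 25-fold higher number from compound 3 to compound 4 (1.40 log units; beyond the scatter), and in place of 4-methoxyphenyl it gives an at least 7.0-fold higher number from compound 2 to compound 4 (0.85 log units; beyond the scatter). The two groups swapped in the first step have the same heavy-atom count, so that count alone does not set the outcome here. The step between compound 1 and compound 4 cannot be read because both values are limits: the limit of > 10000 nM in this assay, at which 2 of the 4 values shown sit.

On these data alone, how much inhibition, if any, compound 4 retains stays unknown. Also open, as far as these compounds go, is whether a phenyl ring carrying an amine or a carboxylic acid would stay near compound 3 or also reach the limit.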